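The source may report more compounds than this note shows. Statements on the series, on what has been measured and on what is new or still open speak of the compounds shown alone.

Measured compounds:
- compound 1, `CN1CCN(c2ccc(C3=NN(C(=O)CCCl)C(c4ccc(N(C)C)cc4)C3)cc2)CC1`: in a functional assay on MDA-MB-231 cells (Homo sapiens) for inhibition, read by sulforhodamine B assay, tested at 10 uM (on this read-out higher numbers stand for more inhibition at the one concentration tested (going by the name of the read-out) and lower numbers for less inhibition), compound 1 gives 2.4%
- compound 2, `CN(C)c1ccc(C2CC(c3ccc(-n4cncn4)cc3)=NN2C(=O)CCCl)cc1`: in this assay compound 2 gives 3.7%

Compound 1 and compound 2 differ only in the group on one aromatic carbon, and the step between them is small: a number 1.3 percentage points higher from compound 1 to compound 2 (within the scatter). Compound 2 thus stands beside compound 1 at the low end of the read-out, the two numbers within the scatter of each other, and neither number is to be called the higher. Both show little inhibition at the single concentration tested.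

Compound 3, `CN(C)c1ccc(C2CC(c3ccc(-n4ccnc4)cc3)=NN2C(=O)CCCl)cc1`, continues the same exchange at the same position: 1H-imidazol-1-yl in place of 1H-1,2,4-triazol-1-yl on an aromatic carbon. Going by the values given here, the only measured step that bears on this position is the one from compound 1 to compound 2, which was within the scatter. On that basis no step beyond the scatter is expected from compound 2 to compound 3 in this assay: a number 0.3 percentage points higher from compound 2 to compound 3 (within the scatter). The number for compound 3 in this assay is estimated at 4%, with a range from 0% to 12%, because compound 2 gives 3.7% and the change is of the same kind as the one already seen.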

Compound 3, a percentage reported as inhibition, at one concentration (the size of the read-out at that concentration, not a potency): 2.1%
Estimate against measurement, compound 3: 1.9 percentage points above, and the stated range covers the measured number.
By their numbers in this assay, from the lowest: compounds 3, 1 and 2 (each within the scatter of the next).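

In this assay, replacing the five-membered aromatic ring with 3 hetero atoms by the one with 2 hetero atoms gives a number 1.6 percentage points lower from compound 2 to compound 3 (within the scatter), so this exchange of 1H-1,2,4-triazol-1-yl for 1H-imidazol-1-yl does not separate the two compounds. The direct exchange of 4-methylpiperazin-1-yl for 1H-imidazol-1-yl gives a number 0.3 percentage points lower from compound 1 to compound 3 (within the scatter), which completes the set: all three groups on this aromatic carbon now lie within the scatter of one another, and all three compounds show little inhibition at the single concentration tested. No measurement shown here accounts for this lack of separation.

As far as these compounds go, it remains open whether any other group at this position, such as a carboxylic acid, a primary amine or a longer alkyl chain, would give a number clearly apart from these three. From the compounds shown here alone, all three compounds also share the dimethylamino group and the 3-chloropropanoyl group, so what a change at either of those places would do in this assay is equally open.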